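Swapping an Aryl Ether for a Substituted Benzyl Group

A few compounds are considered here, and "the series" means these few. Any claim that something is new, unique, unknown or untested is made for them only; others in the source may bear on it.

Three compounds share one core and differ only in the group attached to an aromatic carbon of that core. Compound 1 `COc1cccc(CNCCCNc2ccnc3cc(-c4ccccc4)ccc23)c1O` carries a phenyl there, and in an ADME assay for permeability, using PAMPA, with a stated time of 30 min, at pH 7.4 (a higher number here means that the compound crosses the layer faster, a lower number that the compound crosses the layer more slowly), compound 1 gives 237 10^-6 cm/s. Compound 2 `COc1cccc(CNCCCNc2ccnc3cc(Cc4ccc(C#N)cc4)ccc23)c1O` carries a 4-cyanobenzyl, and in this assay compound 2 gives 23 10^-6 cm/s. Compound 3 `COc1cccc(CNCCCNc2ccnc3cc(Oc4cccc(N(C)C)c4)ccc23)c1O` carries a 3-(dimethylamino)phenoxy, and in this assay compound 3 gives 317 10^-6 cm/s, the highest of the three numbers; this value and that of compound 1 lie within the scatter of each other, while compound 2 sits far lower.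

The change to compound 4 `COc1cccc(CNCCCNc2ccnc3cc(Cc4cccc(C(F)(F)F)c4)ccc23)c1O` is 3-(trifluoromethyl)benzyl in place of 3-(dimethylamino)phenoxy on an aromatic carbon. Within the data shown here, two measured steps bear on it. The step of a 10-fold lower number from compound 1 to compound 2 (1.01 log units; beyond the scatter) shows that a benzyl-type group in place of a plain phenyl went with a large drop, and the step of a 14-fold higher number from compound 2 to compound 3 (1.14 log units; beyond the scatter) shows that replacing that benzyl-type group with the phenoxy went with a large rise. Compound 4 brings a benzyl-type group back, though with trifluoromethyl rather than nitrile, so a drop beyond the scatter is expected, perhaps not as deep as a full return to the level of compound 2. The expected step is a 4.0-fold lower number from compound 3 to compound 4 (0.60 log units; beyond the scatter). Compound 4 is therefore estimated to give about 80 10^-6 cm/s, within a range from 25 10^-6 cm/s to 250 10^-6 cm/s.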

Compound 4, apparent permeability: 23 10^-6 cm/s
Compound 4: the middle estimate sits 3.5-fold (0.54 log units) above what was measured; measured number below the stated range.
By their numbers in this assay, from the lowest: compounds 2 and 4 (each within the scatter of the next); then compounds 1 and 3 (each within the scatter of the next).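

In this assay the second benzyl-type group lands where the first did, with no change at the digits printed from compound 2 to compound 4 (within the scatter) even though a 3-(trifluoromethyl)phenyl stands in place of a 4-cyanophenyl on the carbon that joins the ring to the core. Compound 4 thus shows the full drop and not a partial one, with a 14-fold lower number from compound 3 to compound 4 (1.14 log units; beyond the scatter) and with a 10-fold lower number from compound 1 to compound 4 (1.01 log units; beyond the scatter) as well, so among these four compounds the two benzyl-type groups sit low and the phenyl and the phenoxy sit high, and no compound goes against that split. No measurement here gives a reason for the split.

The change from compound 3 to compound 4 alters both the atom joining the ring to the core, oxygen to carbon, and the substituent on that ring, so the compounds shown cannot say which of the two goes with the drop. An unsubstituted benzyl, a 3-(dimethylamino)benzyl or a 3-(trifluoromethyl)phenoxy at this position would pull those two changes apart, and would show whether any benzyl-type group can stay near the level of compound 1.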